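Methyl in place of chloro: a small step expected

The source may hold more compounds than are shown below. What is called first, only, known or untested is meant among the compounds shown, and "the series" means these compounds.

In a functional assay on MCF7 cells (Homo sapiens) for cytotoxicity, read by MTT assay, with a stated time of 48 h (a higher number here means a weaker inhibitor, a lower number a stronger inhibitor), compound 1 `C=C1CCC[C@]2(C)CCC(c3cn(-c4ccc(OC)cc4)nn3)=CC[C@@]12C` gives 118000 nM, compound 2 `C=C1CCC[C@]2(C)CCC(c3cn(-c4ccc(C(C)=O)cc4)nn3)=CC[C@@]12C` gives 65400 nM, and compound 3 `C=C1CCC[C@]2(C)CCC(c3cn(-c4ccc(Cl)cc4)nn3)=CC[C@@]12C` gives 35100 nM. The three share one core and differ in a single group on the six-membered aromatic ring. Compound 3 stands clear of compound 1, with a 3.4-fold lower number from compound 1 to compound 3 (0.53 log units; beyond the scatter). It cannot be separated from compound 2, since the measurements show a 1.9-fold lower number from compound 2 to compound 3 (0.27 log units; within the scatter). The remaining comparison shows a 1.8-fold lower number from compound 1 to compound 2 (0.26 log units; within the scatter).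

Compound 4 `C=C1CCC[C@]2(C)CCC(c3cn(-c4ccc(C)cc4)nn3)=CC[C@@]12C` keeps the core and carries methyl in place of chloro on an aromatic carbon, para to a large group (methyl in place of chloro on an aromatic carbon). Going by the values given here, no measured compound carries methyl at this place, so the evidence is indirect and rests on how far exchanging this one group has moved the number so far. Among the compounds with values here, only one of the three steps, a 3.4-fold lower number from compound 1 to compound 3 (0.53 log units; beyond the scatter), goes beyond the scatter, and it is modest. A step no larger than that is expected in this assay, more likely toward a higher number than a lower one, and it may stay within the scatter. The estimated step is a 1.7-fold higher number from compound 3 to compound 4 (0.23 log units; within the scatter). For compound 4 the expected value is 60000 nM, with an estimated range of 30000 nM to 120000 nM.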

Compound 4, half-maximal inhibitory concentration: 54900 nM
Estimate against measurement, compound 4: 1.1-fold (0.04 log units) above; the measured number falls inside the stated range.
By their numbers in this assay, from the lowest: compounds 3, 4, 2 and 1 (each within the scatter of the next, the first and the last beyond it).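

In this assay, exchanging chloro for methyl on an aromatic carbon, para to a large group, gives a 1.6-fold higher number from compound 3 to compound 4 (0.19 log units; within the scatter), so at this place these two groups cannot be told apart. Methyl also cannot be separated from acetyl, with a 1.2-fold lower number from compound 2 to compound 4 (0.08 log units; within the scatter), but it does stand clear of methoxy, with a 2.1-fold lower number from compound 1 to compound 4 (0.33 log units; beyond the scatter), a modest step; compound 1 now differs beyond the scatter from both compound 3 and compound 4, while compound 2 remains within the scatter of all three others. Nothing in the information at hand accounts for any of these steps.

With only methoxy, acetyl, chloro and methyl at this place, the compounds shown leave open how the number would respond to an amine, a hydroxyl, a carboxylic acid or a longer chain such as butyl. They also leave open whether any group at this place can move the number much further, or whether the shared core largely sets its level in this cell assay.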